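The source may report more compounds than this note shows. Statements on the series, on what has been measured and on what is new or still open speak of the compounds shown alone.

Going by the values given here, compound 2 `CC(C)(C)c1ccc(Nc2cccc3c2C(=O)N(C2CCC(=O)NC2=O)C3=O)cc1` gives 36% in an assay on FRT-Jurkat cells for inhibition of nuclear factor NF-kappa-B complex (Homo sapiens), read by flow cytometry, with a stated time of 24 h, tested at 10 uM (a lower number here means less inhibition, a higher number more inhibition at the concentration tested (going by the name of the read-out)), and stands as the higher of the two numbers so far. Compound 1 `Cc1ccc(Nc2cccc3c2C(=O)N(C2CCC(=O)NC2=O)C3=O)cc1` gives 9% in this assay. Among the compounds with values here, the one measured step that bears on the present change is a number 27 percentage points higher from compound 1 to compound 2 (beyond the scatter), a modest rise beyond the scatter. Compound 3 `O=C1CCC(N2C(=O)c3cccc(Nc4ccc(O)cc4)c3C2=O)C(=O)N1` differs from compound 2 by hydroxy in place of tert-butyl on an aromatic carbon, placed para to a large group, so the group whose entry carried the measured rise is taken away again and something that is not an alkyl stands in its place. Within the data shown here, no measured step covers a hydroxy here, so the expectation rests on reversing the alkyl step: the gain seen on going to tert-butyl is expected to be handed back, with some chance of falling further. Compound 3 is therefore expected to show a number 26 percentage points lower from compound 2 to compound 3 (beyond the scatter). Compound 3 is estimated at 10%, within -10% to 30%.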

Compound 3, a percentage reported as inhibition, at one concentration (the size of the read-out at that concentration, not a potency): 4%
Compound 3: middle estimate off by 6 percentage points, on the high side; low and high end bracket the measured number.
By their numbers in this assay, from the lowest: compounds 3 and 1 (each within the scatter of the next); then compound 2.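

Hydroxy in place of tert-butyl gives a number 32 percentage points lower from compound 2 to compound 3 (beyond the scatter) in this assay, so the higher number of compound 2 does not carry over to this exchange at the same place on the ring. Hydroxy in place of methyl gives a number 5 percentage points lower from compound 1 to compound 3 (within the scatter), so these two groups cannot be told apart at this place, and among the three groups shown only tert-butyl stands apart from the others. Nothing at hand gives a reason for either step.

Open, going by these compounds, is whether the higher number belongs to tert-butyl alone or extends to other alkyl groups, such as isopropyl or a longer chain like n-butyl. Also open, on these data alone, is whether a methoxy, an amine or a carboxylic acid at this place would stay with compound 1 and compound 3 or reach compound 2.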